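A few compounds are considered here, and "the series" means these few. Any claim that something is new, unique, unknown or untested is made for them only; others in the source may bear on it.

Measured so far in an ADME assay on HaCaT cells (Homo sapiens) for cytotoxicity, read by MTT assay, with a stated time of 72 h; on this read-out higher numbers stand for weaker inhibition and lower numbers for stronger inhibition:
compound 1 `NS(=O)(=O)c1cc(-c2nnc(/C=C/c3ccccc3)o2)c(Cl)cc1SCc1ccccc1` gives 20000 nM;
compound 2 `NS(=O)(=O)c1cc(-c2nnc(/C=C/c3cccc(Cl)c3)o2)c(Cl)cc1SCc1ccccc1` gives 16000 nM.

Among the measured compounds shown here, compound 2 stands at the low end of the two numbers, but the only measured step, a 1.3-fold lower number from compound 1 to compound 2 (0.10 log units; within the scatter), lies within the scatter, so no order between the two is established. The change to compound 3 `NS(=O)(=O)c1cc(-c2nnc(/C=C/c3c(Cl)cccc3Cl)o2)c(Cl)cc1SCc1ccccc1` is 2,6-dichlorophenyl in place of 3-chlorophenyl on a double-bonded chain carbon bound to a double-bonded chain carbon. For the measured compounds named here, the one step that bears on it, a 1.3-fold lower number from compound 1 to compound 2 (0.10 log units; within the scatter), was within the scatter, so for this assay no step beyond the scatter is expected in either direction. For compound 3 the estimate is 14000 nM, with a range of 6000 nM to 35000 nM. That estimate means an expected step of a 1.1-fold lower number from compound 2 to compound 3 (0.06 log units; within the scatter).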

Compound 3, half-maximal inhibitory concentration: 160000 nM
For compound 3 the middle estimate is 11-fold (1.06 log units) below the measured one; the measured number lies above the stated range.
By their numbers in this assay, from the lowest: compounds 2 and 1 (each within the scatter of the next); then compound 3.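

At this position, on a double-bonded chain carbon bound to a double-bonded chain carbon, the aryl group can move this assay beyond the scatter: 2,6-dichlorophenyl in place of 3-chlorophenyl gives a 10-fold higher number from compound 2 to compound 3 (1.00 log units; beyond the scatter), and in place of phenyl it gives an 8.0-fold higher number from compound 1 to compound 3 (0.90 log units; beyond the scatter). Both steps run toward weaker inhibition, whereas the earlier single-chlorine step showed no such separation. No measurement shown here explains the shift.

Going by these compounds, whether the shift needs both chlorines of 2,6-dichlorophenyl remains open. Also open, on these data alone, is how a phenyl carrying an amine or a carboxylic acid would read in this assay.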